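An Ethynyl Replacement on a Shared Nucleoside Core

The source may report more compounds than this note shows. Statements on the series, on what has been measured and on what is new or still open speak of the compounds shown alone.

Compound 1 `Cc1ncnc2c1c(-c1cccs1)cn2[C@@H]1O[C@H](CO)[C@@H](O)[C@H]1O` and compound 2 `Cc1nc(N)c2c(-c3cc4ccccc4o3)cn([C@@H]3O[C@H](CO)[C@@H](O)[C@H]3O)c2n1` share a nucleoside core and were both tested in a functional assay on CEM-DNR-bulk cells (Homo sapiens), read by MTT assay, with a stated time of 72 h; a higher number here means a weaker inhibitor, a lower number a stronger inhibitor. For compound 1 the outcome is a limit of the assay, > 20000 nM. Compound 2 gives 6310 nM, the only number shown. For compound 1 the result is a limit (the limit of > 20000 nM in this assay, at which 1 of the 2 values shown sits). Compound 3 `C#Cc1cn([C@@H]2O[C@H](CO)[C@@H](O)[C@H]2O)c2nc(C)nc(N)c12` differs from compound 2 by ethynyl in place of 1-benzofuran-2-yl on an aromatic carbon. Among the compounds with values here, no measured step between compounds differing in one place exists here, so the expectation rests on the structures alone. A moderate step toward stronger inhibition is expected, a 4.2-fold lower number from compound 2 to compound 3 (0.62 log units; beyond the scatter). Compound 3 is estimated at 1500 nM, ranging from 150 nM to 12000 nM.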

Compound 3, half-maximal inhibitory concentration: 12600 nM
Compound 3: the middle estimate sits 8.4-fold (0.92 log units) below what was measured, and the stated range ends below it.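

In this assay, within the data shown here, ethynyl in place of 1-benzofuran-2-yl on this aromatic carbon gives a 2.0-fold higher number from compound 2 to compound 3 (0.30 log units; within the scatter), the first step in which only this position differs. At this position, a group of 9 heavy atoms with two aromatic rings and a group of 2 heavy atoms with no ring cannot be told apart in this read-out. Nothing shown here accounts for this result.

On these data alone, whether an amine, a carboxylic acid or a longer chain at this position would give a clearly lower number remains open.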